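The source may hold more compounds than are shown below. What is called first, only, known or untested is meant among the compounds shown, and "the series" means these compounds.

Compound 1 `COc1ccc(-c2ccc3c(c2)C(=O)C(=O)N3c2ccc(OC)cc2)cc1` carries an aryl group directly on the lactam nitrogen. In a functional assay on HepG2 cells (Homo sapiens) for antiproliferative activity, read by MTT assay, with a stated time of 48 h (on this read-out lower numbers stand for stronger inhibition and higher numbers for weaker inhibition), compound 1 gives only a limit, > 10000 nM. Compound 2 `COc1ccc(CN2C(=O)C(=O)c3cc(-c4cccc(OC)c4)ccc32)cc1` instead bears a benzyl group on that nitrogen and a 3-methoxyphenyl on the shared core; in this assay compound 2 gives 1890 nM. Compound 2 thus stands as the only numbered result of the pair, the other entry being a limit, as noted in the limit of > 10000 nM in this assay, at which 1 of the 2 values shown sits. Compound 3 `COc1ccc(CN2C(=O)C(=O)c3cc(-c4ccc5ccccc5c4)ccc32)cc1` keeps the benzyl group of compound 2 and differs from it in one place: naphthalen-2-yl in place of 3-methoxyphenyl on an aromatic carbon. Among the compounds with values here, no measured step between two compounds is available to gauge such a change, so any expectation rests on compound 2 alone. The step from compound 2 to compound 3 is expected to be a 1.3-fold lower number from compound 2 to compound 3 (0.10 log units; within the scatter), no larger than the usual scatter. Compound 3 is therefore estimated at 1500 nM in this assay, within 500 nM to 5000 nM.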

Compound 3, half-maximal inhibitory concentration: > 10000 nM
Compound 3: only a limit was reported (the forecaster's own chance of this, stated with the estimate: 10%); at least 6.6-fold (0.82 log units) between middle value and limit.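

In this assay, within the data shown here, the move to naphthalen-2-yl gives an at least 5.2-fold higher number from compound 2 to compound 3 (0.72 log units; beyond the scatter), the first comparison here in which only one place differs. It shows that this aromatic carbon of the shared core does not accept these two aryl groups alike, even with the benzyl group on the nitrogen held constant. Compound 3 gives only a limit, so the step has a lower bound but no measured upper end, and the series now reaches the edge of the read-out: the limit of > 10000 nM in this assay, at which 2 of the 3 values shown sit.

This single step removes the methoxy group and adds a second aromatic ring together, so the compounds shown do not separate the two changes. They also leave open how a plain phenyl, a 3-aminophenyl or a 3-carboxyphenyl group would fare at this position.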